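The compounds below may be only part of what the source reports. "The series", "measured", "known", "first", "only" and "open" are said of these compounds alone.

Measured so far in a functional assay on A549 cells (Homo sapiens) for antiproliferative activity, read by MTT assay, with a stated time of 48 h; a higher number here means a weaker inhibitor, a lower number a stronger inhibitor:
- compound 1 `Cc1ccc2c(c1)C1(C(=O)N2Cc2ccccc2)C(C#N)=C(N)Oc2cc3oc(-c4ccccc4)cc(=O)c3c(O)c21`: > 50000 nM
- compound 2 `COc1ccc2c(c1)C1(C(=O)N2Cc2ccccc2)C(C#N)=C(N)Oc2cc3oc(-c4ccccc4)cc(=O)c3c(O)c21`: > 50000 nM
- compound 3 `N#CC1=C(N)Oc2cc3oc(-c4ccccc4)cc(=O)c3c(O)c2C12C(=O)N(Cc1ccccc1)c1ccc(Br)cc12`: > 50000 nM

Compound 1 gives only a limit in this assay, not a number. Compounds 2 and 3 likewise sit at the limit, so the steps a step that the two limits leave unreadable from compound 1 to compound 2, a step that the two limits leave unreadable from compound 1 to compound 3 and a step that the two limits leave unreadable from compound 2 to compound 3 cannot be read; the whole set rests at the limit of > 50000 nM in this assay, at which 3 of the 3 values shown sit.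

Compound 4 `Cc1ccc2c(c1)C1(C(=O)N2)C(C#N)=C(N)Oc2cc3oc(-c4ccccc4)cc(=O)c3c(O)c21` is the next member. Relative to compound 1 the change is hydrogen in place of benzyl on an amide-type nitrogen in a ring. No measured step touches this nitrogen; the three steps shown alter only a substituent on an aromatic carbon, and all of them are unreadable. Within the data shown here, no step of readable size is therefore expected in this assay, and compound 4 is expected to stay at the limit as well, with a step that the limit leaves unreadable from compound 1 to compound 4. The estimate for compound 4 is 70000 nM, within 25000 nM to 250000 nM.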

Compound 4, half-maximal inhibitory concentration: > 50000 nM
Compound 4 ended at the assay's limit (the forecaster's own chance of this, stated with the estimate: 80%); the middle value lies beyond the limit too.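

Compound 1 and compound 4 both give only a limit, not a number, so no new step can be read, and the series stays where it was: the limit of > 50000 nM in this assay, at which 4 of the 4 values shown sit.
On these data alone, whether any change to the shared core gives a readable number in this assay stays open.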